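This account rests on a few compounds, and the source may have more. Where it says the series, first, only, none or still open, it means among the compounds named here.

Measured compounds:
- compound 1 `O=C1Nc2ccccc2/C1=N/NC(=S)N1CCN(c2ccccc2)CC1`: 24900 nM
- compound 2 `Cc1ccc2c(c1)/C(=N/NC(=S)N1CCN(c3ccccc3)CC1)C(=O)N2`: 14900 nM
- compound 3 `Cc1ccccc1N1CCN(C(=S)N/N=C2\C(=O)Nc3ccc(Cl)cc32)CC1`: 10900 nM

All three were read in a functional assay on MCF7 cells (Homo sapiens) for inhibition, read by MTT assay, with a stated time of 72 h; on this read-out lower numbers stand for stronger inhibition and higher numbers for weaker inhibition. Compound 1 gives 24900 nM and compound 2 gives 14900 nM; the change between them is methyl in place of hydrogen on an aromatic carbon, and the step it made is a 1.7-fold lower number from compound 1 to compound 2 (0.22 log units; within the scatter). Compound 3 gives 10900 nM in this assay; set against compound 2 the two values lie within the scatter of each other, while against compound 1 the gap is beyond it. How the core of compound 3 differs from the core of compound 1 is not broken down here.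

Compound 4 `Cc1ccc(N2CCN(C(=S)N/N=C3\C(=O)Nc4ccc(Cl)cc43)CC2)c(C)c1` is not yet measured. It differs from compound 3 by methyl in place of hydrogen on an aromatic carbon. For the measured compounds named here, this is the same kind of change as the one from compound 1 to compound 2, but the place differs: in the earlier pair the carbon is part of a fused or bridged system of two rings, meta to a fused ring and para to a fused ring, whereas here it is on a six-membered aromatic ring of carbon only, meta to a methyl group and para to a large group. Going by the values given here, the only guide to size is the single earlier step, a 1.7-fold lower number from compound 1 to compound 2 (0.22 log units; within the scatter), which stayed within the scatter; on that basis the step from compound 3 to compound 4 is expected to be small as well, a 1.4-fold lower number from compound 3 to compound 4 (0.13 log units; within the scatter). Compound 4 is therefore estimated at 8000 nM in this assay, with a range from 3500 nM to 18000 nM.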

Compound 4, half-maximal inhibitory concentration: 10800 nM
For compound 4 the middle estimate is 1.4-fold (0.13 log units) below the measured one; the range from low to high includes it.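

In this assay, adding the methyl group to the 2-methylphenyl ring to give the 2,4-dimethylphenyl ring produces a 1.0-fold lower number from compound 3 to compound 4 (0.00 log units; within the scatter), so this step, like the earlier one, stays inside the usual scatter. Set side by side, the two steps do not differ: the same change on two cores in this assay, a 1.7-fold lower number (0.22 log units; within the scatter) from compound 1 to compound 2 and a 1.0-fold lower number (0.00 log units; within the scatter) from compound 3 to compound 4, 1.7-fold (0.22 log units) apart, within the scatter of two such steps. This shows that on these two cores the change has not produced a step beyond the scatter, and that the pair gives no sign of a dependence on the core; it does not show that the change would behave alike on any other core, and because the methyl group sits at a different place in each pair, the role of the core cannot be separated from that of the place.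

The compounds shown leave open whether a group other than methyl at the same place on the 2-methylphenyl ring, such as an ethyl group, a methoxy group, an amine or a carboxylic acid, would give a step beyond the scatter. They also leave open whether a methyl group at other places on either core would do so, and whether these small steps would hold in cell lines other than the one used here.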